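This account rests on a few compounds, and the source may have more. Where it says the series, first, only, none or still open, it means among the compounds named here.

Measured compounds:
- compound 1 `CNCc1cc(-c2cccnc2C#N)n(S(=O)(=O)c2ccccc2)c1` gives 99%
- compound 2 `CNCc1cc(-c2cccnc2Cl)n(S(=O)(=O)c2cccnc2)c1` gives 92%

Notes on the series. Of the compounds shown here, two have been measured in a functional assay on the whole organism (strain Jcl:SD) for inhibition, with Rattus norvegicus as the target, with stated times of 3 min and 3 h, at a dose of 1 mg/kg by the intravenous route (a higher number here means more inhibition at the dose given (going by the name of the read-out), a lower number less inhibition), both at the same dose. Compound 1 gives 99% in this assay, and compound 2 gives 92%. Compound 2 stands as the lower of the two numbers, with compound 1 a number higher by an amount within the scatter, so no order can be read between them; the two numbers are level within the scatter at the dose given.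

Compound 3 `CNCc1cc(-c2cccnc2C#N)n(S(=O)(=O)c2cccnc2)c1` has not been measured. Relative to compound 2 the change is cyano in place of chloro on an aromatic carbon. For the measured compounds named here, no step between measured compounds is available for this change, since compound 1 and compound 2 differ in two places at once. With both measured numbers near the top of the scale, the step expected for compound 3 is none beyond the scatter, at most a small upward drift, given as a number 3 percentage points higher from compound 2 to compound 3 (within the scatter). The estimate for compound 3 in this assay is 95%, expected within 85% to 99%.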

Compound 3, a percentage reported as inhibition, in the whole organism at one dose (the size of the read-out at that dose, not a potency): 48%
Estimate against measurement, compound 3: 47 percentage points above, outside the stated range (below it).
By their numbers in this assay, from the lowest: compound 3; then compounds 2 and 1 (each within the scatter of the next).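

At this position, next to the ring nitrogen and ortho to a large group, cyano in place of chloro is far from a neutral swap in this assay when the sulfonyl sulfur carries pyridin-3-yl (a number 44 percentage points lower from compound 2 to compound 3 (beyond the scatter)). With cyano held in place, pyridin-3-yl in place of phenyl on the sulfonyl sulfur is not neutral either (a number 51 percentage points lower from compound 1 to compound 3 (beyond the scatter)). Cyano occurs in compound 1 and the pyridin-3-yl sulfonyl in compound 2, both near the top of the scale, while compound 3 carries the two together and sits far lower, so within these compounds the two changes cannot be read as independent of each other; no measurement at hand gives a reason for this fall.

As far as these compounds go, whether a methyl, a fluoro or a carboxamide at this position would stay level with compound 2 or fall as cyano does remains open, and so does the result of a pyridin-2-yl on the sulfonyl sulfur with cyano retained. From the compounds shown here alone, because each number is a single-dose read-out, any difference in potency between compound 1 and compound 2 also remains open.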